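A few compounds are considered here, and "the series" means these few. Any claim that something is new, unique, unknown or untested is made for them only; others in the source may bear on it.

Compound 1 `Cc1cccc(Nc2nc(-c3ccnc(-c4cccc5[nH]ccc45)c3)cs2)c1` gives 3100 nM; 3160 nM (2 entries) in a functional assay on RCC4 cells (Homo sapiens) for inhibition, read by XTT assay, with a stated time of 4 days; a higher number here means a weaker inhibitor, a lower number a stronger inhibitor.
Compound 2 `C#Cc1cc(-c2csc(Nc3cccc(C)c3)n2)ccn1` gives 18200 nM in this assay.
Compound 3 `Cc1cccc(Nc2nc(-c3ccnc(-c4cc[nH]n4)c3)cs2)c1` gives 480 nM; 490 nM (2 entries) in this assay.

Compound 2 stands at the high end of the numbers shown in this assay: its single value lies well above those of compound 1 (the several entries of compound 1 in this assay, 3100 nM; 3160 nM (2 entries)) and compound 3 (the several entries of compound 3 in this assay, 480 nM; 490 nM (2 entries)), and two further entries for compound 2 report no single number. Compound 4 `Cc1cccc(Nc2nc(-c3ccnc(Br)c3)cs2)c1` has not been measured in this assay. It differs from compound 2 in one place only: bromo in place of ethynyl on an aromatic carbon. Within the data shown here, since no measured pair shows the effect of this exchange, the direction of the step is open. Compound 1 and compound 3 carry larger groups at the same place and show lower numbers than compound 2, but bromo is a small substituent and offers no such comparison. Compound 4 is therefore expected to remain near compound 2, with a step from compound 2 to compound 4 of a 1.2-fold lower number from compound 2 to compound 4 (0.08 log units; within the scatter) that need not exceed the usual scatter. Compound 4 is estimated at 15000 nM, with a range from 4000 nM to 50000 nM.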

Compound 4, half-maximal inhibitory concentration: 2040 nM
Compound 4: the middle estimate sits 7.4-fold (0.87 log units) above what was measured, and the stated range ends above it.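

In this assay, exchanging ethynyl for bromo on this aromatic carbon, next to the ring nitrogen, gives an 8.9-fold lower number from compound 2 to compound 4 (0.95 log units; beyond the scatter). Among these compounds, this is the first measured step at this place, and it shows that a single bromine atom can give a clearly lower number than the two-carbon ethynyl group. Group size alone does not order the compounds: compound 4, with the smallest group here, stands at a lower number than compound 1 at 3100 nM; 3160 nM (2 entries) but at a higher number than compound 3 at 480 nM; 490 nM (2 entries).

The compounds shown do not tell whether the step reflects the loss of ethynyl or the arrival of bromo. Nor do they show how chloro, an amine or a carboxylic acid at this place would compare with bromo.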